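A few compounds are considered here, and "the series" means these few. Any claim that something is new, unique, unknown or untested is made for them only; others in the source may bear on it.

In an ADME assay on microsomes from liver (Homo sapiens) for metabolic stability, with a stated time of 30 min (on this read-out higher numbers stand for a more stable compound and lower numbers for a less stable compound), compound 2 `CC(=O)c1ccc(N2CCC(CC(=O)Nc3nc4ccccc4o3)CC2)cc1` gives 62%, the higher of the two numbers gathered so far. Compound 1 `CC(C)(C)OC(=O)N1CCC(CC(=O)Nc2nc3cc(Cl)ccc3o2)CC1` differs from compound 2 in two places. In this assay compound 1 gives 43%, a number that sits below compound 2 by more than the usual scatter. Compound 3 `CC(=O)c1ccc(N2CCC(CC(=O)Nc3nc4cc(Cl)ccc4o3)CC2)cc1` differs from compound 2 by chloro in place of hydrogen on an aromatic carbon. Within the data shown here, no measured pair isolates this single change, so the expectation rests on the two numbers alone: a small step downward or none beyond the scatter is expected, a number 6 percentage points lower from compound 2 to compound 3 (within the scatter). Compound 3 is therefore expected to give 56% in this assay, between 38% and 74%.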

Compound 3, percent of the compound remaining: 45%
Estimate against measurement, compound 3: 11 percentage points above, and the stated range covers the measured number.
By their numbers in this assay, from the lowest: compounds 1 and 3 (each within the scatter of the next); then compound 2.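

In this assay, among these compounds, chloro in place of hydrogen on an aromatic carbon gives a number 17 percentage points lower from compound 2 to compound 3 (beyond the scatter), the first reading of this position in which only one thing differs. With chloro present on both compounds, 4-acetylphenyl in place of tert-butoxycarbonyl on an amine nitrogen in a ring gives a number 2 percentage points higher from compound 1 to compound 3 (within the scatter), so these two compounds cannot be told apart here. Nothing at hand explains the chloro step. Going by these compounds, whether fluoro, methyl or a nitrile on this carbon would behave like chloro remains open.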